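The compounds below may be only part of what the source reports. "The series", "measured", "known", "first", "only" and "open" are said of these compounds alone.

Measured so far in a physicochemical assay for solubility; a higher number here means a more soluble compound, a lower number a less soluble compound:
- compound 1 `C[C@H]1C(=O)N(C)C=Cc2cc(OC(CO)CO)ccc21`: >= 142 ug/mL (a limit)
- compound 2 `C[C@H]1C(=O)N(C)C=Cc2cc(C(CO)CO)ccc21`: >= 209 ug/mL (a limit)

Compound 2 is known only through its limit of >= 209 ug/mL, so its true value cannot be placed. Compound 3 `C[C@H]1C(=O)N(C)C=Cc2cc(C(O)CO)ccc21` differs from it as follows: hydroxy in place of hydroxymethyl on a saturated chain carbon bound to an aromatic carbon and a saturated chain carbon. For the measured compounds named here, the only measured step, a step that the two limits leave unreadable from compound 1 to compound 2, gives no size to carry over. No step beyond the scatter is therefore expected in this assay, and no direction can be favoured. The expected change is an at least 1.0-fold lower number from compound 2 to compound 3 (0.01 log units; that floor lies within the scatter). For compound 3 the estimated value is 200 ug/mL, with an expected range from 110 ug/mL to 360 ug/mL.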

Compound 3, solubility: >= 101 ug/mL
Compound 3: no number, only a limit; the forecaster's own chance of this, stated with the estimate: 65%; the middle value is on the limit's open side.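

In this assay, for the compounds shown here, compound 1, compound 2 and compound 3 are each known only through a limit, and no step among them can be read. As far as these compounds go, their true values, and how they rank, stay open.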